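Replacing the Bromofluorophenyl with a Fluorophenyl on the Pyridazinone Nitrogen

The source may hold more compounds than are shown below. What is called first, only, known or untested is meant among the compounds shown, and "the series" means these compounds.

Of the compounds shown here, three sharing one core have been measured in a functional assay on MCF7 cells (Homo sapiens) for cytotoxicity, read by MTT assay, with a stated time of 72 h; a higher number here means a weaker inhibitor, a lower number a stronger inhibitor. Compound 1 `Cc1cc(=O)n(-c2cccc(F)c2)nc1C(=O)Nc1ccc(Oc2ncnc3ccsc23)cc1` gives 6410 nM, compound 2 `Cc1cc(=O)n(-c2ccccc2C(F)(F)F)nc1C(=O)Nc1ccc(Oc2ncnc3ccsc23)c(F)c1` gives 6020 nM, and compound 3 `Cc1cc(=O)n(-c2ccc(Br)cc2F)nc1C(=O)Nc1ccc(Oc2ncnc3ccsc23)c(F)c1` gives 1550 nM. Compound 3 thus stands lowest of the three numbers; its nearest neighbour is compound 2, and compound 1 lies slightly further off, both separated from it by steps beyond the scatter.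

Compound 4 `Cc1cc(=O)n(-c2cccc(F)c2)nc1C(=O)Nc1ccc(Oc2ncnc3ccsc23)c(F)c1` is not yet measured. It differs from compound 3 in one place: 3-fluorophenyl in place of 4-bromo-2-fluorophenyl on an aromatic nitrogen. For the measured compounds named here, the only measured step at this same position is a 3.9-fold lower number from compound 2 to compound 3 (0.59 log units; beyond the scatter), which shows that the group on that aromatic nitrogen can move the number by a modest but real amount. Going by the values given here, compound 1, which carries the same 3-fluorophenyl that enters in compound 4, sits with compound 2 at the high end of the three values, though no single-point step links compound 1 to compound 4.

On that basis compound 4 is expected to give a higher number than compound 3, a step of a 3.2-fold higher number from compound 3 to compound 4 (0.51 log units; beyond the scatter) in this assay, landing back near the values of compound 1 and compound 2. The estimate for compound 4 is 5000 nM, with a range from 2000 nM to 12000 nM.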

Compound 4, half-maximal inhibitory concentration: 9050 nM
The estimate for compound 4 lay 1.8-fold (0.26 log units) below the measured number; low and high end bracket the measured number.
By their numbers in this assay, from the lowest: compound 3; then compounds 2, 1 and 4 (each within the scatter of the next).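

The result shows that the gain at this position belongs to the 4-bromo-2-fluorophenyl of compound 3 and is lost when this assay is read with 3-fluorophenyl in its place (a 5.8-fold higher number from compound 3 to compound 4 (0.77 log units; beyond the scatter)), which makes this a second step beyond the scatter at the position, alongside a 3.9-fold lower number from compound 2 to compound 3 (0.59 log units; beyond the scatter). For the compounds shown here, the 3-fluorophenyl and the 2-(trifluoromethyl)phenyl are not told apart by this read-out (a 1.5-fold higher number from compound 2 to compound 4 (0.18 log units; within the scatter)), and the first reading of fluoro in place of hydrogen on an aromatic carbon, away from this position, also stays within the scatter (a 1.4-fold higher number from compound 1 to compound 4 (0.15 log units; within the scatter)). Nothing available here explains why the group on the aromatic nitrogen moves the number in this way.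

On these data alone, it remains open whether the gain rests on the bromo, on the fluoro beside which it is named in the 4-bromo-2-fluorophenyl group, or only on the two together, as a plain 4-bromophenyl would show. As far as these compounds go, it is also open whether a chloro, a methoxy, an amine or a carboxylic acid on that aryl ring would bring the number down as far as in compound 3.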